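The source may report more compounds than this note shows. Statements on the series, on what has been measured and on what is new or still open speak of the compounds shown alone.

In a functional assay on MDA-MB-231 cells (Homo sapiens) for antiproliferative activity, read by MTT assay, with a stated time of 48 h (a lower number here means a stronger inhibitor, a higher number a weaker inhibitor), compound 1 `CS(=O)(=O)c1ccc(Nc2nccc(Nc3nc4ccccc4s3)n2)cc1` gives 5910 nM, and compound 2 `Cc1ccc2nc(Nc3ccnc(Nc4ccc(S(C)(=O)=O)cc4)n3)sc2c1` gives 4440 nM. Among the measured compounds shown here, the only measured step, a 1.3-fold lower number from compound 1 to compound 2 (0.12 log units; within the scatter), leaves compound 2 with the lower of the two numbers, but within the scatter of compound 1. Compound 3 `COc1ccc2nc(Nc3ccnc(Nc4ccc(S(C)(=O)=O)cc4)n3)sc2c1` differs from compound 2 by methoxy in place of methyl on an aromatic carbon. For the measured compounds named here, the one step bearing on this, a 1.3-fold lower number from compound 1 to compound 2 (0.12 log units; within the scatter), changes the same aromatic carbon and was small, so no step beyond the scatter is expected in this assay, in either direction. The expected step from compound 2 to compound 3 is a 1.1-fold lower number from compound 2 to compound 3 (0.05 log units; within the scatter). Compound 3 is estimated at 4000 nM, with a range from 1800 nM to 9000 nM.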

Compound 3, half-maximal inhibitory concentration: 32700 nM
Compound 3: the middle estimate sits 8.2-fold (0.91 log units) below what was measured; measured number above the stated range.
By their numbers in this assay, from the lowest: compounds 2 and 1 (each within the scatter of the next); then compound 3.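

In this assay this aromatic carbon is not indifferent to what it carries: methoxy in place of methyl gives a 7.4-fold higher number from compound 2 to compound 3 (0.87 log units; beyond the scatter), and methoxy in place of hydrogen gives a 5.5-fold higher number from compound 1 to compound 3 (0.74 log units; beyond the scatter). Methyl in place of hydrogen had stayed within the scatter, so that result does not extend to methoxy. Nothing measured here offers a reason for the weaker number of compound 3. On these data alone, it remains open whether a hydroxyl, an amine or a chlorine atom on this carbon would go with methyl or with methoxy, and whether methoxy on another carbon of that ring would give a similar step.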